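Swapping a sulfone ring for a dimethylcyclohexyl group

The source may hold more compounds than are shown below. What is called first, only, known or untested is meant among the compounds shown, and "the series" means these compounds.

Compound 1 `c1cncc(CNCCCCN(C[C@H]2Cc3ccccc3CN2)[C@H]2CCCc3cccnc32)c1`, compound 2 `c1ccc2c(c1)CN[C@@H](CN(CCCCNCC1CCOCC1)[C@H]1CCCc3cccnc31)C2` and compound 3 `O=S1(=O)CCC(CNCCCCN(C[C@H]2Cc3ccccc3CN2)[C@H]2CCCc3cccnc32)CC1` share one core and differ only in the group attached to the outer amine nitrogen. In a functional assay on cells for antagonist activity at C-X-C chemokine receptor type 4 (Homo sapiens), read by fluorescence and calcium flux, with stated times of 25 min and 90 s (a lower number here means a stronger inhibitor, a higher number a weaker inhibitor), compound 1 gives 15.3 nM, compound 2 gives 52.9 nM and compound 3 gives 17 nM. Compound 3 therefore stands at the second highest of the three numbers, close to compound 1 and apart from compound 2. The step of a 3.5-fold higher number from compound 1 to compound 2 (0.54 log units; beyond the scatter) was modest, whereas a 1.1-fold higher number from compound 1 to compound 3 (0.05 log units; within the scatter) stayed within the scatter and a 3.1-fold lower number from compound 2 to compound 3 (0.49 log units; beyond the scatter) was modest in the other direction. Compound 4 `CC1(C)CCC(NCCCCN(C[C@H]2Cc3ccccc3CN2)[C@H]2CCCc3cccnc32)CC1` carries the change (4,4-dimethylcyclohexyl in place of (1,1-dioxothian-4-yl)methyl on an amine nitrogen). Among the measured compounds shown here, no measured step exchanges a ring of carbon only for one bearing hetero atoms, nor drops the linking chain carbon, so the bearing of the three steps is only indirect: a ring without acceptors was the weakest case seen in compound 2, which gave 52.9 nM. Compound 4 is therefore expected to show a modest rise, a 2.4-fold higher number from compound 3 to compound 4 (0.37 log units; beyond the scatter). The estimated value of compound 4 is 40 nM, within 12 nM to 130 nM.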

Compound 4, half-maximal inhibitory concentration: 77.6 nM
For compound 4 the middle estimate is 1.9-fold (0.29 log units) below the measured one; measured number inside the range.
By their numbers in this assay, from the lowest: compounds 1 and 3 (each within the scatter of the next); then compounds 2 and 4 (each within the scatter of the next).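

In this assay, placing 4,4-dimethylcyclohexyl on the amine nitrogen gives a 4.6-fold higher number from compound 3 to compound 4 (0.66 log units; beyond the scatter) and a 5.1-fold higher number from compound 1 to compound 4 (0.71 log units; beyond the scatter), so this position accepts a ring of carbon only but does not match the (1,1-dioxothian-4-yl)methyl or (pyridin-3-yl)methyl groups. The remaining step, a 1.5-fold higher number from compound 2 to compound 4 (0.17 log units; within the scatter), stays within the scatter, so compound 2 goes against any simple link between hydrogen-bond acceptors and a lower number, since its (oxan-4-yl)methyl group does not separate from the carbon-only ring of compound 4. Nothing in the available data explains these differences.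

The change replaces the ring and removes the saturated chain carbon in a single step, so the contribution of each remains unresolved. A cyclohexylmethyl group would separate the two, and a piperidin-4-yl group would test a ring amine at this position.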